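A few compounds are considered here, and "the series" means these few. Any claim that something is new, unique, unknown or untested is made for them only; others in the source may bear on it.

Of the compounds shown here, three have so far been measured in a functional assay on C6 cells (Rattus norvegicus) for cytotoxicity, read by MTT assay, with a stated time of 24 h, tested at 6 ug/mL; a lower number here means a stronger effect, a higher number a weaker effect of the compound at the concentration tested. Compound 1 `Cn1cnnc1SCC(=O)N/N=c1/scc(-c2ccc(C#N)cc2)n1-c1ccccc1` gives 70.2%. Compound 2 `COc1ccc(-c2cs/c(=N/NC(=O)CSc3ncccn3)n2-c2ccccc2)cc1` gives 89.6%, while compound 3 `COc1ccc(-c2cs/c(=N/NC(=O)CSc3nnc(C)s3)n2-c2ccccc2)cc1` gives 57.9%. Compound 1 therefore stands second highest of the three numbers, nearest to compound 3 and furthest from compound 2, both gaps beyond the scatter. Among the compounds with values here, the only step between measured compounds that differ in one place is a number 31.7 percentage points lower from compound 2 to compound 3 (beyond the scatter), a large fall, and it shows that exchanging the group on the sulfur can move this assay strongly. Compound 4 `Cn1nnnc1SCC(=O)N/N=c1/scc(-c2ccc(C#N)cc2)n1-c1ccccc1` differs from compound 1 by 1-methyl-1H-tetrazol-5-yl in place of 4-methyl-4H-1,2,4-triazol-3-yl on a sulfur. This is not the same exchange as the one measured, and compounds 2 and 3 also differ from compound 1 elsewhere, so the measured step bears on it only loosely. A modest step is expected, a number 5.2 percentage points lower from compound 1 to compound 4 (within the scatter), its direction uncertain. Compound 4 is thus estimated at 65%, with a range from 45% to 85%.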

Compound 4, a percentage reported as activity, at one concentration (the size of the read-out at that concentration, not a potency): 63.5%
The estimate for compound 4 lay 1.5 percentage points above the measured number; the range from low to high includes it.
By their numbers in this assay, from the lowest: compounds 3, 4 and 1 (each within the scatter of the next, the first and the last beyond it); then compound 2.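

In this assay, replacing the 4-methyl-4H-1,2,4-triazol-3-yl on the sulfur with 1-methyl-1H-tetrazol-5-yl gives a number 6.7 percentage points lower from compound 1 to compound 4 (within the scatter), so a five-membered aromatic ring with 3 hetero atoms and one with 4 hetero atoms cannot be told apart at this position. The earlier step, a number 31.7 percentage points lower from compound 2 to compound 3 (beyond the scatter), showed that a change on the sulfur can matter, whereas this one shows that not every change there does, at least on the core of compound 1. Nothing measured here offers a reason for this result.

From the compounds shown here alone, it remains open whether the same exchange would also stay within the scatter on the core of compound 3. Also open, going by these compounds, is how an open-chain group on the sulfur, such as a carboxylic acid or an amine on a longer chain, would compare with these rings.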